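Swapping the amine on the tert-butyl compound

The compounds below may be only part of what the source reports. "The series", "measured", "known", "first", "only" and "open" are said of these compounds alone.

In an ADME assay on microsomes from liver (Homo sapiens) for metabolic stability, read by LC-MS, using NADPH, with a stated time of 1 h, tested at 10 uM (on this read-out higher numbers stand for a longer-lived compound and lower numbers for a shorter-lived compound), compound 2 `Cn1nc(CN2CCCC2)nc1-c1ccc(C(C)(C)C)cc1` gives 1.99 h, compound 1 `Cn1nc(CN2CCCC2)nc1-c1ccc(C2(C(F)(F)F)CC2)cc1` gives 2.87 h and compound 3 `Cn1nc(CN2CCCC2)nc1-c1cccc(C2(C(F)(F)F)CC2)c1` gives 1.46 h. Compound 2 lies within the scatter of both neighbours, so its place among the three carries little weight. The next change leads to compound 4 `CN(Cc1nc(-c2ccc(C(C)(C)C)cc2)n(C)n1)CC1CC1` and reads ((cyclopropylmethyl)(methyl)amino in place of pyrrolidin-1-yl on a saturated chain carbon bound to an aromatic carbon); the tert-butyl group stays. Among the compounds with values here, the only measured step, a 1.4-fold lower number from compound 1 to compound 2 (0.16 log units; within the scatter), lies within the scatter and replaces a different group. Within the data shown here, no measured step replaces pyrrolidin-1-yl, so the data give no direct size for this change. No shift beyond the scatter is expected in this assay, and the expected step is a 1.2-fold lower number from compound 2 to compound 4 (0.07 log units; within the scatter). For compound 4 the estimated half-life is 1.7 h, with an expected range of 0.8 h to 3.5 h.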

Compound 4, half-life: 1.02 h
The estimate for compound 4 lay 1.7-fold (0.22 log units) above the measured number; low and high end bracket the measured number.
By their numbers in this assay, from the lowest: compounds 4, 3, 2 and 1 (each within the scatter of the next, the first and the last beyond it).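

In this assay, the amine on the saturated chain carbon bound to an aromatic carbon now has its first measured step: a 2.0-fold lower number from compound 2 to compound 4 (0.29 log units; within the scatter) for (cyclopropylmethyl)(methyl)amino in place of pyrrolidin-1-yl. With the tert-butyl group held constant, this change gives no shift that can be told from the scatter. Nothing available explains the reading at this position.

Still open, from the compounds shown here alone, is whether a morpholine or a piperidine here would give a step beyond the scatter. Also open, going by these compounds, is whether the same amine swap reads alike with 1-(trifluoromethyl)cyclopropyl in place of tert-butyl.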